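Swapping a cyclobutyl amide for a methyl carbamate

A few compounds are considered here, and "the series" means these few. Any claim that something is new, unique, unknown or untested is made for them only; others in the source may bear on it.

Of the compounds shown here, two have been measured for cytotoxicity in a functional assay on WI-38 VA13 cells (Homo sapiens) for cytotoxicity; a lower number here means that less compound is needed, a higher number that more compound is needed for the effect. Compound 1, with structure `Cc1ccccc1C(=O)Nc1ccc2nc(NC(=O)C3CCCCC3)sc2c1`, gives 0.085 ug/mL. Compound 2, with structure `O=C(Nc1ccc2nc(NC(=O)C3CCC3)sc2c1)c1c(Cl)cccc1Cl`, gives 0.013 ug/mL, the lower of the two numbers; the gap to compound 1 lies beyond the usual scatter of this measurement, so compound 2 is the more potent of the pair.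

Compound 3, with structure `COC(=O)Nc1nc2ccc(NC(=O)c3c(Cl)cccc3Cl)cc2s1`, has not yet been measured. It differs from compound 2 in one place: methoxy in place of cyclobutyl on a carbonyl carbon. For the measured compounds named here, no measured pair in this set shows this particular change, so its effect is unknown here. The expectation is a modest step toward a higher number, a 2.3-fold higher number from compound 2 to compound 3 (0.36 log units; beyond the scatter), possibly no larger than the scatter itself. Compound 3 is therefore estimated at 0.03 ug/mL in this assay, within a range from 0.006 ug/mL to 0.15 ug/mL.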

Compound 3, half-maximal effective concentration: 0.0095 ug/mL
Compound 3: the middle estimate sits 3.2-fold (0.50 log units) above what was measured, and the stated range covers the measured number.
By their numbers in this assay, from the lowest: compounds 3 and 2 (each within the scatter of the next); then compound 1.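

In this assay, methoxy in place of cyclobutyl on a carbonyl carbon gives a 1.4-fold lower number from compound 2 to compound 3 (0.14 log units; within the scatter), so this one change leaves the two compounds indistinguishable. For the compounds shown here, this is the first direct reading at this position, since compounds 1 and 2 differ in more than one place. It shows that the ring of carbon can be replaced by a group with no ring, fewer heavy atoms and an oxygen without moving the number beyond the usual scatter. Nothing available here explains this result.

A single pair cannot show how much freedom this position allows: an amine on the same carbonyl carbon, or a longer chain such as butoxy, could give a different number. Going by these compounds, whether methoxy would behave the same way in place of the cyclohexyl of compound 1 also remains open.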